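Removing a nitro group: what the measurements so far suggest

The source may report more compounds than this note shows. Statements on the series, on what has been measured and on what is new or still open speak of the compounds shown alone.

Measured so far in an assay on cells for inhibition of HSP60/HSP10 (Homo sapiens), with a stated time of 60 min; a lower number here means a stronger inhibitor, a higher number a weaker inhibitor:
- compound 1 `Cc1ccc(S(=O)(=O)Nc2ccc3oc(-c4ccccc4)nc3c2)cc1` gives > 100000 nM, a limit rather than a number.
- compound 2 `O=[N+]([O-])c1cc(S(=O)(=O)Nc2ccc(-c3nc4ccccc4o3)cc2)ccc1Cl` gives 17000 nM.
- compound 3 `N#Cc1ccc(S(=O)(=O)Nc2ccc(-c3nc4cc(NS(=O)(=O)c5ccc(C#N)cc5)ccc4o3)cc2)cc1` gives 49000 nM.

Of the two actual numbers, compound 2 holds the lower one, and compound 3 stands at a number beyond the scatter above it, so compound 2 is the stronger inhibitor of this pair. The reading for compound 1 is only a limit of the measurement (the limit of > 100000 nM in this assay, at which 1 of the 3 values shown sits).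

The next compound, compound 4 `O=S(=O)(Nc1ccc(-c2nc3ccccc3o2)cc1)c1ccc(Cl)cc1`, is compound 2 with one change: hydrogen in place of nitro on an aromatic carbon. For the measured compounds named here, no measured pair differs by this change alone, so its size cannot be read off from the numbers in hand. Going by the values given here, the expectation is a moderate step toward a weaker inhibitor in this assay, probably just beyond the scatter, since the only compounds without that group, compound 1 and compound 3, both sit higher than compound 2, though each also differs in other ways.

Compound 4 is therefore estimated at about 40000 nM in this assay, with a plausible range from 12000 nM to 150000 nM. Compound 4 would then stand at an expected step of a 2.4-fold higher number from compound 2 to compound 4 (0.37 log units; beyond the scatter) from its parent.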

Compound 4, half-maximal inhibitory concentration: 61000 nM
For compound 4 the middle estimate is 1.5-fold (0.18 log units) below the measured one; the measured number falls inside the stated range.
By their numbers in this assay, from the lowest: compound 2; then compounds 3 and 4 (each within the scatter of the next). At a limit, above all of these: compound 1.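

In this assay, for the compounds shown here, compounds 2 and 4 form the first pair that differs in one place only, so the nitro group ortho to a chloro group can now be judged on its own: putting hydrogen in its place gives a 3.6-fold higher number from compound 2 to compound 4 (0.55 log units; beyond the scatter). That is a modest step but one beyond the scatter, which means that on this scaffold, and with the chloro group kept, the nitro group goes with stronger inhibition, though the compound does not depend on it for a measurable number. Compound 1 alone remains at a limit rather than a number, and compound 4 does not join it: the limit of > 100000 nM in this assay, at which 1 of the 4 values shown sits.

The pair compares nitro only with hydrogen, so it cannot tell whether something about nitro itself matters or whether any group on this carbon would serve as well, and an amine, a methoxy group or a carboxylic acid in the same place would begin to settle that. The part played by the chloro group also stays open, as no pair shown changes that group alone, and the numbers give no reason for the step.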